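A few compounds are considered here, and "the series" means these few. Any claim that something is new, unique, unknown or untested is made for them only; others in the source may bear on it.

Measured in a physicochemical assay for solubility, read by spectrophotometry, in phosphate buffer, with a stated time of 18 h, at pH 7.4; on this read-out lower numbers stand for lower solubility and higher numbers for higher solubility:
- compound 1 `CCc1ccc(-c2nc3c(c(C)nn3-c3ccccc3)c(-c3ccccc3C#N)c2C#N)cc1`: 2400 nM
- compound 2 `CCc1ccc(-c2nc3c(c(C)nn3-c3ccccc3)c(-c3ccccc3Cl)c2C#N)cc1`: 1700 nM

Only these two compounds have been measured so far, and compound 2, at 1700 nM, lies within the scatter of compound 1. Compound 3 `CCc1ccc(-c2nc3c(c(C)nn3-c3ccccc3)c(-c3ccccc3OC)c2C#N)cc1` keeps the shared core of compound 2 and carries methoxy in place of chloro on an aromatic carbon, ortho to a large group: methoxy in place of chloro on an aromatic carbon. For the measured compounds named here, one measured step bears on this change, a 1.4-fold lower number from compound 1 to compound 2 (0.15 log units; within the scatter), which is chloro in place of cyano on an aromatic carbon and stays within the scatter. Going by the values given here, no measurement yet covers methoxy itself, so this single small step is thin evidence. On that basis, no shift beyond the scatter is expected in this assay, and the estimated step is a 1.2-fold higher number from compound 2 to compound 3 (0.07 log units; within the scatter). For compound 3 the expected value is 2000 nM, with an estimated range from 1000 nM to 4000 nM.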

Compound 3, solubility: 7800 nM
The estimate for compound 3 lay 3.9-fold (0.59 log units) below the measured number; measured number outside the range, above it.
By their numbers in this assay, from the lowest: compounds 2 and 1 (each within the scatter of the next); then compound 3.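

In this assay, this place on the aromatic ring, ortho to a large group, proves able to move the read-out: methoxy gives a 4.6-fold higher number from compound 2 to compound 3 (0.66 log units; beyond the scatter) when it stands in place of chloro and a 3.3-fold higher number from compound 1 to compound 3 (0.51 log units; beyond the scatter) when it stands in place of cyano. Chloro and cyano had stayed within the scatter of each other, so the two compounds alone could have suggested a place where the choice of group made little difference, and methoxy is the first group here to break from them. Nothing available explains the rise, and the count of one hydrogen-bond acceptor entering with methoxy cannot be tied to it.

As far as these compounds go, whether the rise is particular to methoxy or would also appear with an amine, a hydroxyl or a longer chain such as ethoxy remains open. Also open, from the compounds shown here alone, is whether methoxy would give a similar step on a different core.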